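Hydroxyphenyl isomers in a weakly cytotoxic anilino series

This account rests on a few compounds, and the source may have more. Where it says the series, first, only, none or still open, it means among the compounds named here.

Measured so far in a functional assay on MCF7 cells (Homo sapiens) for cytotoxicity, read by MTT assay, with a stated time of 48 h; on this read-out lower numbers stand for stronger inhibition and higher numbers for weaker inhibition:
Compound 1, `Fc1cccc(Nc2nc(-c3cccc(F)c3)nc3ccc(F)cc23)c1`, gives 48700 nM.
Compound 2, `Fc1cccc(-c2nc(Nc3ccccc3F)c3cc(F)ccc3n2)c1`, gives > 50000 nM, a limit of the assay and not a number.
Compound 3, `Oc1ccc(Nc2nc(-c3cccc(F)c3)nc3ccc(F)cc23)cc1`, gives > 50000 nM, likewise a limit and not a number.

Going by the values given here, compound 3 thus stands at the floor of this assay; only a limit is known for it. the limit of > 50000 nM in this assay, at which 2 of the 3 values shown sit, marks where two of the three values sit, so the whole series so far is weak. The steps already measured all change the group on the ring nitrogen: an at least 1.0-fold higher number from compound 1 to compound 2 (0.01 log units; that floor lies within the scatter) and an at least 1.0-fold higher number from compound 1 to compound 3 (0.01 log units; that floor lies within the scatter) are floors that lie within the scatter, and a step that the two limits leave unreadable from compound 2 to compound 3 cannot be read. Among the compounds with values here, none of them moves a hydroxyl from one position to another, so no measured step bears directly on the change to compound 4, `Oc1cccc(Nc2nc(-c3cccc(F)c3)nc3ccc(F)cc23)c1`. That change is 3-hydroxyphenyl in place of 4-hydroxyphenyl on a nitrogen on an aromatic ring. With three weak or unmeasurable values and no readable trend, compound 4 is expected to sit near the same floor, and an at least 1.1-fold lower number from compound 3 to compound 4 (0.04 log units; that floor lies within the scatter) is estimated as no step beyond the scatter. Compound 4 is therefore expected at 45000 nM, within 15000 nM to 150000 nM, with a fair chance that only a limit is reported.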

Compound 4, half-maximal inhibitory concentration: > 50000 nM
Compound 4: no number, only a limit; the forecaster's own chance of this, stated with the estimate: 60%; middle value at least 1.1-fold (0.04 log units) from the limit.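

In this assay compound 4 gives > 50000 nM as a limit of the assay and not a number, so 3-hydroxyphenyl on this nitrogen yields no measurable value, just as 4-hydroxyphenyl did not. The steps from compound 2 and compound 3 to compound 4 cannot be read, which leaves this hydroxyl shift without a measurable effect on the read-out. The one readable step is an at least 1.0-fold higher number from compound 1 to compound 4 (0.01 log units; that floor lies within the scatter) and it separates hydroxy from fluoro on this aromatic ring by no more than the scatter, while the series stays pressed against one boundary: the limit of > 50000 nM in this assay, at which 3 of the 4 values shown sit.

Any true gap between the 4-hydroxyphenyl and 3-hydroxyphenyl groups remains hidden behind the limits. As far as these compounds go, whether an aminophenyl or a carboxyphenyl group on this nitrogen would bring a measurable value remains open.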